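This account rests on a few compounds, and the source may have more. Where it says the series, first, only, none or still open, it means among the compounds named here.

For the measured compounds named here, compound 2 `O=C(Nc1cccc2[nH]ncc12)NC1CCN(Cc2ccccc2)c2ccc(F)cc21` gives 66 nM in a functional assay for antagonist activity at transient receptor potential cation channel subfamily V member 1 (Homo sapiens), read by calcium flux (a higher number here means a weaker inhibitor, a lower number a stronger inhibitor), the higher of the two numbers known so far, whereas compound 1 `O=C(Nc1cccc2[nH]ncc12)NC1CCOc2c(OC(F)(F)F)cccc21` gives 5 nM, a gap that lies beyond the scatter. Compound 3 `COc1ccc2c(c1)C(NC(=O)Nc1cccc3[nH]ncc13)CCN2Cc1ccccc1` has not yet been measured; it differs from compound 2 by methoxy in place of fluoro on an aromatic carbon. Going by the values given here, no measured pair shows this exchange, so its effect in this assay cannot be read from the numbers at hand. The expected step is a 1.1-fold lower number from compound 2 to compound 3 (0.04 log units; within the scatter), which need not exceed the scatter. The estimate for compound 3 in this assay is 60 nM, with a range from 20 nM to 200 nM.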

Compound 3, half-maximal inhibitory concentration: 160 nM
Compound 3: middle estimate off by 2.7-fold (0.43 log units), on the low side; the range from low to high includes it.
By their numbers in this assay, from the lowest: compound 1; then compound 2; then compound 3.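

In this assay, methoxy in place of fluoro on this aromatic carbon gives a 2.4-fold higher number from compound 2 to compound 3 (0.38 log units; beyond the scatter), a modest step that lies beyond the scatter. For the compounds shown here, this is the first direct reading of a single change, and it shows that the number responds to the group at this position. No available evidence accounts for the step. Open, on these data alone, is how a smaller group such as chloro, or an amine, would compare at this position. Also open, as far as these compounds go, is whether the exchange of fluoro for methoxy would give a similar step with a different group in place of the benzyl on the ring nitrogen.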